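Ester series on a shared core: chloro at the meta position

The compounds below may be only part of what the source reports. "The series", "measured", "known", "first", "only" and "open" are said of these compounds alone.

Compound 3, `CC1=CC[C@H](C(C)C)c2cc(C)c(OC(=O)c3ccccc3)cc21`, carries a benzoate on a shared core. In a functional assay on HCT-15 cells (Homo sapiens) for antiproliferative activity, read by sulforhodamine B assay, with a stated time of 48 h, tested at 50 uM (a higher number here means more inhibition at the concentration tested (going by the name of the read-out), a lower number less inhibition), compound 3 gives 49.5%, the lowest of the two numbers recorded, while its carbamate counterpart compound 2, `CC1=CC[C@H](C(C)C)c2cc(C)c(OC(=O)Nc3ccccc3)cc21`, gives 92%. Among the measured compounds shown here, the one step measured, a number 42.5 percentage points lower from compound 2 to compound 3 (beyond the scatter), concerns the carbonyl substituent, not the aromatic ring that compound 4 alters. Compound 1, `COc1cccc(C(=O)Oc2cc3c(cc2C)[C@@H](C(C)C)CC=C3C)c1`, a benzoate bearing methoxy on the ring, is reported as "not active" (no number reported), without a number.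

Compound 4, `CC1=CC[C@H](C(C)C)c2cc(C)c(OC(=O)c3cccc(Cl)c3)cc21`, differs from compound 3 by chloro in place of hydrogen on an aromatic carbon. For the measured compounds named here, no measured step bears directly on this change; the only ring-substituted analog, compound 1, is reported as "not active" (no number reported), whereas compound 3 gives 49.5%. The account therefore expects a step of a number 14.5 percentage points lower from compound 3 to compound 4 (beyond the scatter) in this assay, downward but uncertain, because compound 1 was "not active" (no number reported) while compound 3 gave 49.5%. Compound 4 is estimated at 35%, within 5% to 65%.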

Compound 4, a percentage reported as inhibition, at one concentration (the size of the read-out at that concentration, not a potency): 5.3%
For compound 4 the middle estimate is 29.7 percentage points above the measured one; measured number inside the range.
By their numbers in this assay, from the lowest: compound 4; then compound 3; then compound 2.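

The change of phenyl to 3-chlorophenyl gives the shown series its first numerical reading of a substituent on the benzoate ring: in this assay, chloro on this aromatic carbon, meta to a large group, produces a number 44.2 percentage points lower from compound 3 to compound 4 (beyond the scatter). The ring therefore matters as much as the carbonyl substituent did, and chloro removes nearly all of the inhibition that the unsubstituted benzoate retained. Against the carbamate, the gap widens to a number 86.7 percentage points lower from compound 2 to compound 4 (beyond the scatter), with both the carbonyl substituent and the ring differing, and no available evidence accounts for the drop.

Going by these compounds, whether an amine or a carboxylic acid at this ring position would keep the inhibition of compound 3 remains open. So does whether chloro at the same place on the anilino ring of compound 2 would lower its number.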